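Rearranging the Amide Heterocycle of Compound 2

A few compounds are considered here, and "the series" means these few. Any claim that something is new, unique, unknown or untested is made for them only; others in the source may bear on it.

Three compounds share an amide linking a benzylic sulfonyl group to a fused aromatic pair of rings, and all were tested in a functional assay on A2780 cells (Homo sapiens) for inhibition, read by sulforhodamine B assay, with a stated time of 72 h; on this read-out lower numbers stand for stronger inhibition and higher numbers for weaker inhibition. Compound 1 `O=C(NCc1ccc(S(=O)(=O)c2cc(F)cc(F)c2)cc1)c1cc2ccncc2o1` gives 9 nM in this assay. Compound 2 `O=C(NCc1ccc(S(=O)(=O)N2CCCCC2)cc1)c1cc2ccncc2[nH]1` gives 1700 nM, which is the second highest of the three numbers: compound 3 `O=C(NCc1ccc(S(=O)(=O)c2ccccc2)cc1)c1nc2cnccc2[nH]1` gives 5400 nM, a higher number than that of compound 2, while compound 1 lies far below it. Compound 4 `O=C(NCc1ccc(S(=O)(=O)N2CCCCC2)cc1)c1ccn2ccnc2c1` has not yet been measured. It differs from compound 2 only at the carbonyl carbon, where (a group of 9 heavy atoms (7 carbon, 2 nitrogen; one five-membered aromatic ring with 2 hetero atoms, one six-membered aromatic ring with 1 hetero atom) in place of a group of 9 heavy atoms (7 carbon, 2 nitrogen; one five-membered aromatic ring with 1 hetero atom, one six-membered aromatic ring with 1 hetero atom), on a carbonyl carbon); the two have the same atoms, joined differently. Among the measured compounds no single step isolates such a rearrangement, so its effect is uncertain, and the spread from compound 1 to compound 3 shows that changes to this part of the molecule can matter. The step expected is a 1.1-fold lower number from compound 2 to compound 4 (0.05 log units; within the scatter), which is not expected to go beyond the usual scatter. Compound 4 is therefore estimated at 1500 nM, within a range from 300 nM to 8000 nM.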

Compound 4, half-maximal inhibitory concentration: > 10000 nM
Compound 4 gave a limit, no number; the forecaster's own chance of this, stated with the estimate: 10%; middle value at least 6.6-fold (0.82 log units) from the limit.
By their numbers in this assay, from the lowest: compound 1; then compound 2; then compound 3. At a limit, above all of these: compound 4.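

The same atoms joined differently on a carbonyl carbon are not interchangeable here: this assay gives an at least 5.8-fold higher number from compound 2 to compound 4 (0.76 log units; beyond the scatter). Compound 4 reaches only a limit, > 10000 nM, so it has no exact number, and the step has a lower bound but no upper one: the limit of > 10000 nM in this assay, at which 1 of the 4 values shown sits. Within the data shown here, this is the first single step to isolate a rearrangement of this ring pair, which goes from 1 hydrogen-bond donor and 1 acceptor to 0 donors and 2 acceptors, and it shows that this rearrangement alone can make the number clearly higher.

Nothing shown reveals which part of the rearrangement matters, or whether the same step would have a similar effect with a different sulfonyl group. From the compounds shown here alone, it also remains open whether adding a small group, such as an amine or a methyl, to the ring pair in compound 4 would bring the number down.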